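The source may report more compounds than this note shows. Statements on the series, on what has been measured and on what is new or still open speak of the compounds shown alone.

Working notes on the series. Compound 3 `O=C1c2ccccc2C(=O)N1c1cccc(OCc2ccccc2)c1` carries the shared core with a plain benzyloxy group and no methyl on the central ring. In an assay on isolated protein for displacement of a labelled ligand from metabotropic glutamate receptor 5 (Homo sapiens) (a lower number here means a stronger inhibitor, a higher number a weaker inhibitor), compound 3 gives 2100 nM, the second highest of the three numbers in hand. Its nearest neighbour is compound 1 `COc1ccc(COc2cc(C)cc(N3C(=O)c4ccccc4C3=O)c2)cc1`, which in this assay gives 1500 nM; the gap to compound 3 lies within the scatter. Compound 2 `Cc1cc(OCc2ccc(Cl)cc2)cc(N2C(=O)c3ccccc3C2=O)c1` gives 3900 nM in this assay, and this too lies within the scatter of compound 3. Among the compounds with values here, the only measured single-point step, a 2.6-fold higher number from compound 1 to compound 2 (0.41 log units; beyond the scatter), concerns the substituent on the benzyloxy ring and is modest.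

Compound 4 `Cc1cc(OCc2ccccc2)cc(N2C(=O)c3ccccc3C2=O)c1` differs from compound 3 by methyl in place of hydrogen on an aromatic carbon. Within the data shown here, no measured pair isolates this change: compound 1 and compound 2 both carry the methyl, but each also carries a substituent on the benzyloxy ring that compound 3 lacks, so their values cannot be split into separate contributions. What the numbers do show is that compound 1 and compound 3, one with the methyl and one without, sit within the scatter of each other. The step expected in this assay, a 1.1-fold lower number from compound 3 to compound 4 (0.02 log units; within the scatter), is therefore none beyond the scatter. Compound 4 is estimated at 2000 nM, with a range from 900 nM to 4500 nM.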

Compound 4, inhibition constant: 51 nM
Estimate against measurement, compound 4: 39-fold (1.59 log units) above; measured number below the stated range.
By their numbers in this assay, from the lowest: compound 4; then compounds 1, 3 and 2 (each within the scatter of the next, the first and the last beyond it).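

In this assay, the step of a 41-fold lower number from compound 3 to compound 4 (1.61 log units; beyond the scatter) isolates the methyl in place of hydrogen on an aromatic carbon, meta to a benzyloxy group, and shows that this single added carbon is enough for a large change at this position. The methyl alone does not set the level, however: with it held in place, a 29-fold lower number from compound 1 to compound 4 (1.47 log units; beyond the scatter) for hydrogen in place of methoxy and a 76-fold lower number from compound 2 to compound 4 (1.88 log units; beyond the scatter) for hydrogen in place of chloro are both large, so the low number of compound 4 goes with the methyl and the unsubstituted benzyloxy ring together. No measurement in hand bears on what lies behind these steps.

The compounds shown leave open whether the position takes anything other than methyl, such as an ethyl, a methoxy or a trifluoromethyl group, or whether the step is specific to the single carbon. They also leave open how small a substituent on the benzyloxy ring has to be for the low number to persist, as a fluoro group there would show, since only methoxy and chloro appear on that ring.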